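The compounds below may be only part of what the source reports. "The series", "measured", "known", "first", "only" and "open" are said of these compounds alone.

Compound 1 `CCNC(=O)c1oc2nc(-c3ccccc3)cc(C(F)(F)F)c2c1N` has the highest number of the three measured compounds in a functional assay on HepG2 cells (Homo sapiens) for antiproliferative activity, read by MTT assay (a higher number here means a weaker inhibitor, a lower number a stronger inhibitor), giving 42800 nM. Compound 2 `CCNC(=O)c1oc2nc(-c3cccs3)cc(C(F)(F)F)c2c1N` gives 12100 nM, and compound 3 `Nc1c(C(=O)NC2CCCC2)oc2nc(-c3cccs3)cc(C(F)(F)F)c12` gives 20800 nM. The aromatic swap is a 3.5-fold lower number from compound 1 to compound 2 (0.55 log units; beyond the scatter), while the amide change is a 1.7-fold higher number from compound 2 to compound 3 (0.24 log units; within the scatter).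

Compound 4 `Nc1c(C(=O)N/N=C/c2ccc(Cl)cc2)oc2nc(-c3ccccc3)cc(C(F)(F)F)c12` differs from compound 1 at the amide-type nitrogen: a group of 9 heavy atoms (7 carbon, 1 nitrogen, 1 chlorine; one six-membered aromatic ring of carbon only) in place of a group of 2 heavy atoms (2 carbon; no ring), on an amide-type nitrogen. Only the ethyl-to-cyclopentyl step at that nitrogen bears on this change, and it stayed within the scatter, though the entering group here is far larger and of a different kind, so the guidance is weak. A step of a 1.7-fold lower number from compound 1 to compound 4 (0.23 log units; within the scatter) in this assay is therefore expected, with wide uncertainty. Compound 4 is estimated at 25000 nM, within 7000 nM to 90000 nM.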

Compound 4, half-maximal inhibitory concentration: 12100 nM
Compound 4: the middle estimate sits 2.1-fold (0.32 log units) above what was measured; the range from low to high includes it.
By their numbers in this assay, from the lowest: compounds 2, 4 and 3 (each within the scatter of the next); then compound 1.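

At the amide-type nitrogen, the ethyl-to-cyclopentyl change had stayed within the scatter, so this position could have seemed insensitive. In this assay, the much larger chlorine-bearing aromatic group gives a 3.5-fold lower number from compound 1 to compound 4 (0.55 log units; beyond the scatter), showing that a change at this nitrogen can move the number beyond the scatter and that a large group here does not raise it. No measurement available here explains this step.

From the compounds shown here alone, whether the chlorine, the aromatic ring or the double bond matters remains open. A benzyl group at this nitrogen would help separate these parts.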